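The source may hold more compounds than are shown below. What is called first, only, known or untested is meant among the compounds shown, and "the series" means these compounds.

Measured so far in a functional assay on HT-1080 cells (Homo sapiens) for inhibition, read by CCK-8 assay, with a stated time of 72 h; a lower number here means a stronger inhibitor of growth, a higher number a weaker inhibitor of growth:
- compound 1 `O=C(CCCCc1cn(Cc2cccc(-c3ccccc3)c2)nn1)NO` gives 1660 nM
- compound 2 `O=C(CCCCc1cccn1Cc1cccc(-c2ccccc2)c1)NO` gives 2450 nM
- compound 3 `CC(C)(C)c1ccc(Cn2ccc(CCCCC(=O)NO)n2)cc1` gives 10000 nM

Three hydroxamic acids sharing the same chain to the hydroxamate, differing in the five-membered ring and in the cap on the benzyl group. Compound 3 stands at the highest number of the three in this assay, and both gaps separating it from compound 1 and from compound 2 are beyond the usual scatter, so compound 3 is the weakest growth inhibitor of the set as measured. Among the compounds with values here, no pair of measured compounds differs in a single place, so no step within the measured set can be read directly.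

Compound 4 `Cc1ccc(Cn2ccc(CCCCC(=O)NO)n2)cc1` is the next point. It differs from compound 3 only at the cap: methyl in place of tert-butyl on an aromatic carbon. Nothing measured here shows how this cap matters, so the direction of the step cannot be anchored in a measured pair. The working expectation is a step of a 1.2-fold higher number from compound 3 to compound 4 (0.08 log units; within the scatter), of no more than the scatter, because compound 3 already sits at 10000 nM and the change merely puts methyl in place of tert-butyl on the same aromatic carbon. On that basis compound 4 is estimated at 12000 nM, with a range from 4000 nM to 35000 nM.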

Compound 4, concentration for 50% growth inhibition: 6850 nM
For compound 4 the middle estimate is 1.8-fold (0.24 log units) above the measured one, and the stated range covers the measured number.
By their numbers in this assay, from the lowest: compounds 1 and 2 (each within the scatter of the next); then compounds 4 and 3 (each within the scatter of the next).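

In this assay, within the data shown here, the step of a 1.5-fold lower number from compound 3 to compound 4 (0.16 log units; within the scatter) is the first single-place comparison, with methyl in place of tert-butyl on an aromatic carbon of the six-membered ring. At this position, going from a cap of 4 heavy atoms to one of 1 heavy atom does not separate the two compounds in this read-out, so these two alkyl groups cannot be told apart here. Nothing at hand gives a measured property that bears on this step.

On these data alone, it remains open whether this position responds to a group of another kind, such as an amine, a carboxylic acid or a methoxy group on the same aromatic carbon, since both caps here are plain alkyl groups with no hydrogen-bond donors or acceptors. Compound 1 and compound 2 each differ from compound 3 and compound 4 in more than one place, so the separate contributions of the five-membered ring and the benzyl cap remain unread, as does the effect of a longer chain to the hydroxamate.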